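Acetamido for cyano in a series with little spread

This account rests on a few compounds, and the source may have more. Where it says the series, first, only, none or still open, it means among the compounds named here.

In a functional assay on SMMC-7721 cells (Homo sapiens) for cytotoxicity, read by MTT assay, with a stated time of 24 h (a lower number here means a stronger inhibitor, a higher number a weaker inhibitor), compound 1 (`Cc1ccc(S(=O)(=O)N2C/C(=C\c3cccnc3)C(=O)/C(=C/c3ccccc3F)C2)cc1`) gives 10300 nM and compound 2 (`O=C1/C(=C/c2cccnc2)CN(S(=O)(=O)c2ccc(Br)cc2)C/C1=C\c1ccccc1F`) gives 9100 nM while compound 3 (`N#Cc1ccc(S(=O)(=O)N2C/C(=C\c3cccnc3)C(=O)/C(=C/c3ccccc3F)C2)cc1`) gives 15400 nM with all three sharing one core. The numbers do not separate compound 3 from either of the others, as the steps (a 1.5-fold higher number from compound 1 to compound 3 (0.17 log units; within the scatter)) and (a 1.7-fold higher number from compound 2 to compound 3 (0.23 log units; within the scatter)) show.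

Compound 4 (`CC(=O)Nc1ccc(S(=O)(=O)N2C/C(=C\c3cccnc3)C(=O)/C(=C/c3ccccc3F)C2)cc1`) has acetamido in place of cyano on an aromatic carbon, para to a large group (acetamido in place of cyano on an aromatic carbon), the same difference reading 4-cyanophenyl to 4-acetamidophenyl.

The measured steps that bear on this are the exchanges at that same carbon. Besides the two steps to compound 3, there is the exchange of methyl for bromo (a 1.1-fold lower number from compound 1 to compound 2 (0.05 log units; within the scatter)). All three stayed within the scatter, so exchanges among these groups have not moved the number in this assay so far. Going by the values given here, no measured compound carries acetamido, so this support is only indirect, and no step beyond the scatter is expected. The estimated change is small (a 1.4-fold lower number from compound 3 to compound 4 (0.15 log units; within the scatter)) and leans only toward the middle of the measured numbers. For compound 4 the expected value is 11000 nM with an estimated range from 5000 nM to 25000 nM in this account.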

Compound 4, half-maximal inhibitory concentration: 10900 nM
Compound 4: the middle estimate sits 1.0-fold (0.00 log units) above what was measured; the range from low to high includes it.
By their numbers in this assay, from the lowest: compounds 2, 1, 4 and 3 (each within the scatter of the next).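

Acetamido differs from cyano by more heavy atoms and by adding a hydrogen-bond donor, yet in this assay this exchange stays within the scatter: a 1.4-fold lower number from compound 3 to compound 4 (0.15 log units; within the scatter). Its steps from the other two groups stay within the scatter as well, with a 1.2-fold higher number from compound 2 to compound 4 (0.08 log units; within the scatter) and a 1.1-fold higher number from compound 1 to compound 4 (0.02 log units; within the scatter), so among these four compounds, methyl, bromo, cyano and acetamido on this aromatic carbon, para to a large group, cannot be told apart by this read-out, and the series now includes a group carrying the amide hydrogen without any step beyond the scatter. No measurement is available that bears on why the number stays put at this position.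

The compounds shown leave open whether any group on this carbon can move the number beyond the scatter, for example a carboxylic acid, an amine or a longer chain. They also leave open whether the same insensitivity would hold with a different remainder, as all four share the rest of their structure, including the 2-fluorophenyl group.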